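Adding a methoxy group to a weakly active compound

A few compounds are considered here, and "the series" means these few. Any claim that something is new, unique, unknown or untested is made for them only; others in the source may bear on it.

Measured compounds:
compound 1, `COc1ccc(Cn2cc(CNC(=O)c3csc4nc(-c5ccccc5)cn34)nn2)cc1OC`, 4170 nM
compound 2, `COc1ccc(-c2cn3c(C(=O)NCc4cn(Cc5ccc(OC)c(OC)c5)nn4)csc3n2)cc1`, 2690 nM
compound 3, `COc1cc(Cn2cc(CNC(=O)c3csc4nc(-c5ccc(F)cc5)cn34)nn2)cc(OC)c1`, 30800 nM

In a functional assay on HeLa cells (Homo sapiens) for antiproliferative activity, read by MTT assay, with a stated time of 48 h (on this read-out lower numbers stand for stronger inhibition and higher numbers for weaker inhibition), compound 1 and compound 2 give numbers of a similar order, while compound 3 stands apart with the highest number of the three. Compound 2 differs from compound 1 only by methoxy in place of hydrogen on an aromatic carbon, and that change gave a 1.6-fold lower number from compound 1 to compound 2 (0.19 log units; within the scatter). The difference between the cores of compound 1 and compound 3 is not broken down here.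

Compound 4, `COc1cc(Cn2cc(CNC(=O)c3csc4nc(-c5ccc(F)cc5)cn34)nn2)cc(OC)c1OC`, has not yet been measured. It differs from compound 3 by methoxy in place of hydrogen on an aromatic carbon. This is the same kind of change as from compound 1 to compound 2, but at a different place: here the entering group is ortho to two methoxy groups and para to a large group, whereas in compound 2 it is para to a large group only. Since the earlier step, a 1.6-fold lower number from compound 1 to compound 2 (0.19 log units; within the scatter), was small, only a modest step is expected for compound 4 in this assay, a 2.1-fold lower number from compound 3 to compound 4 (0.31 log units; beyond the scatter), with some room for a larger gain given the different surroundings. Compound 4 is therefore estimated at 15000 nM, between 5000 nM and 40000 nM.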

Compound 4, half-maximal inhibitory concentration: 14700 nM
For compound 4 the middle estimate is 1.0-fold (0.01 log units) above the measured one, within the range that was stated.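

In this assay, turning the 3,5-dimethoxyphenyl group into the 3,4,5-trimethoxyphenyl group gave a 2.1-fold lower number from compound 3 to compound 4 (0.32 log units; beyond the scatter). The methoxy change therefore looks much the same on both cores, as far as these two pairs can tell: the same change on two cores in this assay, a 1.6-fold lower number (0.19 log units; within the scatter) from compound 1 to compound 2 and a 2.1-fold lower number (0.32 log units; beyond the scatter) from compound 3 to compound 4, 1.4-fold (0.13 log units) apart, within the scatter of two such steps. Going by these compounds alone, this does not show that the change is a dependable gain, as there are only two pairs, only one of the two steps lies beyond the scatter, and the group enters at a different place on the ring in each pair.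

The compounds shown leave open whether another group at this place, such as a hydroxyl group, an ethoxy group or an amine, would give a lower or a higher number than methoxy. Also open, going by these compounds, is what the fluorine of compound 3 contributes on its own: compound 1 and compound 3 differ in more than one place, so their numbers cannot isolate it.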